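Swapping ethyl for phenyl at the chain end

The source may report more compounds than this note shows. Statements on the series, on what has been measured and on what is new or still open speak of the compounds shown alone.

Of the compounds shown here, two with a shared core have so far been measured in an ADME assay on MT4 cells (Homo sapiens) for cytotoxicity, read by MTT assay; a higher number here means that more compound is tolerated, a lower number that less compound is tolerated. Compound 1 (`CCCCC1C(=O)N(O)C(=O)c2ccccc21`) gives 25400 nM, and compound 2 (`CCCCCC1C(=O)N(O)C(=O)c2ccccc21`) gives 98300 nM, the higher of the two numbers. On these data alone, compound 3 (`O=C1c2ccccc2C(CCCc2ccccc2)C(=O)N1O`) is untested and differs from compound 2 by phenyl in place of ethyl on a saturated chain carbon, three bonds along the chain from a saturated ring carbon. Put simply, this is phenyl in place of ethyl on a saturated chain carbon, three bonds along the chain from a saturated ring carbon.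

Among the compounds with values here, only one measured step offers any guidance: a 3.9-fold higher number from compound 1 to compound 2 (0.59 log units; beyond the scatter). This modest step, beyond the scatter, also alters the chain, but it swaps hydrogen for methyl and brings in no ring, so it is a loose guide. The direction of the new step cannot be read from it with confidence. Since compound 2 already stands at the top of the measured pair with 98300 nM, a modest fall in this assay seems the likelier outcome. The expected change is a 2.3-fold lower number from compound 2 to compound 3 (0.37 log units; beyond the scatter). For compound 3, the estimated value is 42000 nM, with an expected range of 13000 nM to 125000 nM.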

Compound 3, half-maximal cytotoxic concentration: 5200 nM
Estimate against measurement, compound 3: 8.1-fold (0.91 log units) above, outside the stated range (below it).
By their numbers in this assay, from the lowest: compound 3; then compound 1; then compound 2.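

Within the data shown here, the chain can do more than nudge the number upward: in this assay, phenyl in place of ethyl, on a saturated chain carbon three bonds along the chain from a saturated ring carbon, gives a 19-fold lower number from compound 2 to compound 3 (1.28 log units; beyond the scatter) and so reverses the direction of the only earlier step, in a large move. The fall also holds against the other measured compound, with a 4.9-fold lower number from compound 1 to compound 3 (0.69 log units; beyond the scatter) in this modest step, which leaves compound 3 with the lowest number of the three and shows that less of it is tolerated than of either compound with a plain chain. No measurement shown bears on the reason for this fall.

On these data alone, whether the drop belongs to the aromatic ring itself or simply comes with a larger group at the end of the chain stays open, and a cyclohexyl group or a longer plain chain at the same place would help to separate those two readings. Three compounds also cannot say how an amine or a carboxylic acid at this place would read in this assay and whether such a group would move the number up or down.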